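Swapping the ring on the piperazine nitrogen of a benzimidazole amide

The source may hold more compounds than are shown below. What is called first, only, known or untested is meant among the compounds shown, and "the series" means these compounds.

Of the compounds shown here, two sharing one core have been measured so far. Compound 1 `O=C(CN1CCN(c2ccccn2)CC1)Nc1nc2ccccc2[nH]1` carries a pyridin-2-yl group on an amine nitrogen in a ring, and in a functional assay, read by spectrophotometry, with a stated time of 30 min, tested at 50 ug/mL (a lower number here means a weaker effect, a higher number a stronger effect of the compound at the concentration tested), compound 1 gives 50%. Among the compounds with values here, compound 2 `O=C(CN1CCN(c2ncccn2)CC1)Nc1nc2ccccc2[nH]1` carries a pyrimidin-2-yl group in the same place, and in this assay compound 2 gives 31%, the lower of the two numbers; the only measured step, a number 19 percentage points lower from compound 1 to compound 2 (beyond the scatter), separates them.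

Compound 3 `COc1ccccc1N1CCN(CC(=O)Nc2nc3ccccc3[nH]2)CC1` differs from compound 2 in that place: 2-methoxyphenyl in place of pyrimidin-2-yl on an amine nitrogen in a ring. Within the data shown here, no measured step covers this exact exchange; the step from compound 1 to compound 2 only shows that changing the ring on this nitrogen can shift the read-out by a modest amount. Since a carbon-only ring has not been tested here, the direction is open, but a move back toward the level of compound 1 seems as likely as a further loss.

Compound 3 is therefore expected to give about 45% in this assay, within 25% to 70%, which would mean an estimated step of a number 14 percentage points higher from compound 2 to compound 3 (beyond the scatter).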

Compound 3, a percentage reported as activity, at one concentration (the size of the read-out at that concentration, not a potency): 35.7%
Compound 3: middle estimate off by 9.3 percentage points, on the high side, within the range that was stated.
By their numbers in this assay, from the lowest: compounds 2 and 3 (each within the scatter of the next); then compound 1.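

With 2-methoxyphenyl, this amine nitrogen now carries a ring of carbon only, and in this assay the exchange for pyrimidin-2-yl gives a number 4.7 percentage points higher from compound 2 to compound 3 (within the scatter), so a ring of carbon only and a ring with 2 hetero atoms cannot be told apart at this position. The exchange for pyridin-2-yl gives a number 14.3 percentage points lower from compound 1 to compound 3 (beyond the scatter), which leaves the pyridin-2-yl ring of compound 1 as the one that stands apart from the other two and shows that the read-out here does not simply fall as hetero atoms are taken out of the ring or added to it. No measurement at hand explains why these three rings fall out this way.

As far as these compounds go, how much of the result for compound 3 belongs to the methoxy group and how much to the carbon-only ring remains open, and a plain phenyl ring on the same nitrogen would separate the two. From the compounds shown here alone, whether this position needs an aromatic ring at all also remains open, a question that a benzyl group or a simple methyl group there would address.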